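The source may hold more compounds than are shown below. What is called first, only, known or untested is meant among the compounds shown, and "the series" means these compounds.

Solubility measures how much of a compound stays dissolved in water, and a small set of compounds gives a first picture here. In a physicochemical assay for solubility, in phosphate buffer, with a stated time of 18 h, at pH 7.4 (on this read-out lower numbers stand for lower solubility and higher numbers for higher solubility), compound 1 (`COc1ccc2ncnc(-n3nc(-c4ccccn4)nc3N)c2c1`) gives 7000 nM, compound 2 (`COc1cc2ncnc(-n3nc(-c4ccc(Cl)cc4)nc3N)c2cc1OC`) gives 1000 nM and compound 3 (`CCN(CC)c1nc(-n2nc(-c3ccccn3)nc2N)c2cc(OC)c(OC)cc2n1`) gives 6000 nM. Compound 3 therefore stands level with compound 1, within the usual scatter of repeated measurements, and clearly apart from compound 2, whose number is lower by more than that scatter.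

The next compound to consider is compound 4 (`COc1cc2nc(N)nc(-n3nc(-c4ccccn4)nc3N)c2cc1OC`). It differs from compound 3 in one place: amino in place of diethylamino on an aromatic carbon, on a six-membered aromatic ring with 2 nitrogen, between two ring nitrogen atoms (amino in place of diethylamino on an aromatic carbon).

For the measured compounds named here, no two measured compounds differ in only one place, so no measured step shows what this kind of change does. Going by the values given here, the only guide is that compound 1 at 7000 nM and compound 3 at 6000 nM lie within the scatter of each other, although their structures differ in more than one place. On these data alone, with so little evidence, no change beyond the scatter is expected, and the direction stays open. The expected result is a 1.2-fold lower number from compound 3 to compound 4 (0.08 log units; within the scatter). Compound 4 is estimated at 5000 nM. The estimated range for compound 4 is wide, from 1500 nM to 15000 nM.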

Compound 4, solubility: 27000 nM
Estimate against measurement, compound 4: 5.4-fold (0.73 log units) below; the measured number lies above the stated range.
By their numbers in this assay, from the lowest: compound 2; then compounds 3 and 1 (each within the scatter of the next); then compound 4.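

In this assay, for the compounds shown here, this is the first step in which only one place changes, and it shows that the position between two ring nitrogen atoms matters for this read-out: amino in place of diethylamino gives a 4.5-fold higher number from compound 3 to compound 4 (0.65 log units; beyond the scatter). The earlier compounds shown here could not show this, since no two of them differed in only one place. The swap changes several things at once, as diethylamino has 5 heavy atoms and 0 hydrogen-bond donors while amino has 1 heavy atom and 1 hydrogen-bond donor, and no measurement shown here ties the step to any one of these differences.

The compounds shown leave open whether the number follows the size of the group, the hydrogen-bond donor it brings, or both; methylamino and dimethylamino at this same position would help pull those two differences apart. They also leave open whether the same swap gives a step of similar size when the rest of the molecule changes, for example with a chlorophenyl group in place of the pyridine ring's position on the shared core.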